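This account rests on a few compounds, and the source may have more. Where it says the series, first, only, none or still open, it means among the compounds named here.

Measured in a functional assay on U-373MG ATCC cells (Homo sapiens), read by thymidine incorporation; a higher number here means a weaker inhibitor, a lower number a stronger inhibitor:
- compound 1 `CCCCCCCCCCCCCCCCO[C@H]1O[C@H](COCC(CO)(CO)CO)[C@@H](O)[C@H](O)[C@H]1NC(=O)CCCC`: 27.3 uM
- compound 2 `CCCCCCCCCCCCCCCCO[C@H]1O[C@H](COC[C@H](O)CO)[C@@H](O)[C@H](O)[C@H]1NC(=O)CCCC`: 4.9 uM
- compound 3 `CCCCCCCCCCCCCCCCO[C@H]1O[C@H](COCC(O)CO)[C@@H](O)[C@H](O)[C@H]1NC(=O)CCCC`: 4.6 uM

Compound 3 has the lowest number of the three, at 4.6 uM, but it cannot be separated from compound 2, since a 1.1-fold lower number from compound 2 to compound 3 (0.03 log units; within the scatter). That pair differs only in whether one stereocentre is drawn with a configuration, as the fact that one of compounds 2 and 3 is drawn with a defined configuration and the other without, at the place where they differ records. Compound 3 stands clearly apart from compound 1, as a 5.9-fold lower number from compound 1 to compound 3 (0.77 log units; beyond the scatter) shows.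

Compound 4 `CCCCCCCCCCCCCCCCO[C@H]1O[C@H](COCC(O)CO)[C@@H](O)[C@H](O)[C@H]1NC(=O)CCCCCCCCCCCCCCC` keeps the rest of compound 3 and carries undecyl in place of hydrogen on a saturated chain carbon, four bonds along the chain from a carbonyl carbon. Within the data shown here, no measured step touches this chain. Among the measured compounds shown here, the only steps beyond the scatter, a 5.6-fold lower number from compound 1 to compound 2 (0.75 log units; beyond the scatter) and a 5.9-fold lower number from compound 1 to compound 3 (0.77 log units; beyond the scatter), lie at the other end of the molecule, so they serve only as a rough guide to size. The direction is a judgement, not a measured trend, and the range is kept wide for that reason.

The expected change is a 3.3-fold higher number from compound 3 to compound 4 (0.51 log units; beyond the scatter), a modest move towards a higher number in this assay.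

For compound 4 the estimated value is 15 uM, with an expected range of 4 uM to 60 uM.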

Compound 4, concentration for 50% inhibition: 3.3 uM
Compound 4: middle estimate off by 4.5-fold (0.66 log units), on the high side, outside the stated range (below it).
By their numbers in this assay, from the lowest: compounds 4, 3 and 2 (each within the scatter of the next); then compound 1.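

In this assay, undecyl in place of hydrogen, on a saturated chain carbon four bonds along the chain from a carbonyl carbon, gives a 1.4-fold lower number from compound 3 to compound 4 (0.14 log units; within the scatter). Among these compounds, this is the first reading at this chain: the added undecyl leaves compound 4 indistinguishable from compound 3, so in this pair the number does not respond to the change. The information available offers no explanation for this result.

Open, as far as these compounds go, is how the number behaves with a shorter chain such as hexyl at this place, or with an amine or a carboxylic acid at the chain end. Also open, from the compounds shown here alone, is whether undecyl has the same outcome when 2-hydroxy-1,1-bis(hydroxymethyl)ethyl, as in compound 1, replaces the 1,2-dihydroxyethyl group of compound 3.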